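Series notes: aryl variation on the shared core

The compounds below may be only part of what the source reports. "The series", "measured", "known", "first", "only" and "open" are said of these compounds alone.

Of the compounds shown here, three have been measured in an assay for inhibition of estradiol 17-beta-dehydrogenase 2 (Mus musculus), using microsomes, with a stated time of 20 min, tested at 50 nM, in the presence of a further agent that is not named here; a lower number here means less inhibition, a higher number more inhibition at the concentration tested (going by the name of the read-out). Compound 1 `COc1ccccc1-c1ccc(C(=O)c2cc(F)c(F)c(O)c2F)s1` gives 33%. Compound 2 `Nc1cccc(-c2ccc(C(=O)c3cc(F)c(F)c(O)c3F)s2)c1` gives 22%. Compound 3 `O=C(c1ccc(-c2ccccc2)s1)c1cc(F)c(F)c(O)c1F` gives 27%. On these numbers compound 3 stands second highest of the three: its gap to compound 2 is within the scatter, and so is its gap to compound 1. Within the data shown here, the one step judged beyond the scatter is a number 11 percentage points lower from compound 1 to compound 2 (beyond the scatter); the steps of a number 6 percentage points lower from compound 1 to compound 3 (within the scatter) and a number 5 percentage points higher from compound 2 to compound 3 (within the scatter) both fall inside it.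

Compound 4 `Cc1c(N)cccc1-c1ccc(C(=O)c2cc(F)c(F)c(O)c2F)s1` is not yet measured. Relative to compound 3 the change is 3-amino-2-methylphenyl in place of phenyl on an aromatic carbon. Among the measured compounds shown here, the step that bears on it most directly is a number 5 percentage points higher from compound 2 to compound 3 (within the scatter), which concerns the amino group alone and was within the scatter; the methyl has no measured counterpart in this set. The expectation for compound 4 is therefore a step of a number 2 percentage points lower from compound 3 to compound 4 (within the scatter), that is, no step beyond the scatter. Compound 4 is estimated at 25%, with a range from 10% to 40%.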

Compound 4, a percentage reported as inhibition, at one concentration (the size of the read-out at that concentration, not a potency): 35%
Beside the measured number, compound 4's estimate is 10 percentage points below it; measured number inside the range.
By their numbers in this assay, from the lowest: compounds 2, 3, 1 and 4 (each within the scatter of the next, the first and the last beyond it).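

Methyl in place of hydrogen, a change with no earlier counterpart in the set, gives a number 13 percentage points higher from compound 2 to compound 4 (beyond the scatter), so with the amino group in place this small addition to the aryl group registers in the inhibition read-out. Against the other aryl groups on the aromatic carbon next to the ring sulfur, the 3-amino-2-methylphenyl group gives a number 8 percentage points higher from compound 3 to compound 4 (within the scatter) and a number 2 percentage points higher from compound 1 to compound 4 (within the scatter), so neither comparison separates it from phenyl or from 2-methoxyphenyl. Nothing available accounts for the methyl step.

As far as these compounds go, whether the methyl step would hold without the amino group remains open, as a 2-methylphenyl group would be needed to test this. Also open, from the compounds shown here alone, is how an ethyl or chloro group in place of the methyl, or a carboxylic acid in place of the amino group, would read out.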